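Hydroxy added to the chlorophenyl arm of compound 1

This account rests on a few compounds, and the source may have more. Where it says the series, first, only, none or still open, it means among the compounds named here.

Compound 1 `COc1cccc(/C=C2\CCC/C(=C\c3cccc(Cl)c3)C2=O)c1OC`: 9100 nM in a functional assay on SW-620 cells (Homo sapiens) for cytotoxicity, read by MTT assay, with a stated time of 72 h; on this read-out lower numbers stand for stronger inhibition and higher numbers for weaker inhibition
Compound 2 `COc1cccc(/C=C2\CCC/C(=C\c3ccc(Cl)cc3)C2=O)c1OC`: 11100 nM
Compound 3 `COc1cccc(/C=C2\CCC/C(=C\c3ccc(O)cc3)C2=O)c1OC`: > 20000 nM, a limit of the assay and not a number

Compound 1 holds the lower of the two plain numbers, with compound 2 close by: a 1.2-fold higher number from compound 1 to compound 2 (0.09 log units; within the scatter). For compound 3 the assay gives only a limit, (the limit of > 20000 nM in this assay, at which 1 of the 3 values shown sits). Compound 4 `COc1cccc(/C=C2\CCC/C(=C\c3ccc(O)c(Cl)c3)C2=O)c1OC` differs from compound 1 as follows: hydroxy in place of hydrogen on an aromatic carbon. Going by the values given here, two measured steps bear on this. Moving the whole arm to a hydroxyphenyl gave an at least 2.1-fold higher number from compound 1 to compound 3 (0.34 log units; beyond the scatter), and swapping chloro for hydroxy gave an at least 1.8-fold higher number from compound 2 to compound 3 (0.25 log units; that floor lies within the scatter). Adding a hydroxy while keeping the chloro is expected to weaken the number by a modest amount, a 1.6-fold higher number from compound 1 to compound 4 (0.22 log units; within the scatter). Compound 4 is therefore estimated at 15000 nM, between 7000 nM and 30000 nM.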

Compound 4, half-maximal inhibitory concentration: 16800 nM
Compound 4: middle estimate off by 1.1-fold (0.05 log units), on the low side; the measured number falls inside the stated range.
By their numbers in this assay, from the lowest: compounds 1, 2 and 4 (each within the scatter of the next). At a limit, above all of these: compound 3.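

In this assay hydroxy ortho to a chloro group gives a 1.8-fold higher number from compound 1 to compound 4 (0.27 log units; within the scatter) and the full arm swap gives a 1.5-fold higher number from compound 2 to compound 4 (0.18 log units; within the scatter) so compounds 1, 2 and 4 cannot be told apart. Chloro in place of hydrogen on the hydroxyphenyl arm gives an at least 1.1-fold lower number from compound 3 to compound 4 (0.07 log units; that floor lies within the scatter) and this floor does not separate the pair. Compound 3 remains a limit of the assay and not a number: the limit of > 20000 nM in this assay, at which 1 of the 4 values shown sits.

Open, as far as these compounds go, is whether an amine or a carboxylic acid at this position, para to a large group, would read apart from compound 4. Also open, from the compounds shown here alone, is whether a methoxy there would do so.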